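Piperidin-1-yl to 4-Methylpiperazin-1-yl on a Shared Core

This account rests on a few compounds, and the source may have more. Where it says the series, first, only, none or still open, it means among the compounds named here.

Measured compounds:
compound 1, `COc1cc2ncnc(N3CCCc4ccccc43)c2cc1NC(=O)/C=C/CN1CCCCC1`, gives 3930 nM in a functional assay on MCF7 cells (Homo sapiens) for antiproliferative activity, read by MTT assay, with a stated time of 72 h; on this read-out higher numbers stand for weaker inhibition and lower numbers for stronger inhibition
compound 2, `COc1cc2ncnc(N3CCCc4ccccc43)c2cc1NC(=O)/C=C/CN1CCN(C)CC1`, gives 8560 nM
compound 3, `O=C(/C=C/CN1CCCCC1)Nc1cc2c(N3CCCc4ccccc43)ncnc2cc1O[C@@H]1CCOC1`, gives 4450 nM

Two changes have been made on the shared core. The first is 4-methylpiperazin-1-yl in place of piperidin-1-yl on a saturated chain carbon bound to a double-bonded chain carbon, and it gave a 2.2-fold higher number from compound 1 to compound 2 (0.34 log units; beyond the scatter). The second is oxolan-3-yl in place of methyl on an oxygen on an aromatic ring, which gave a 1.1-fold higher number from compound 1 to compound 3 (0.05 log units; within the scatter), so compound 1 and compound 3 cannot be told apart in this assay. Compound 3 also lies within the scatter of compound 2.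

Compound 4, `CN1CCN(C/C=C/C(=O)Nc2cc3c(N4CCCc5ccccc54)ncnc3cc2O[C@@H]2CCOC2)CC1`, has not been measured. It differs from compound 3 by 4-methylpiperazin-1-yl in place of piperidin-1-yl on a saturated chain carbon bound to a double-bonded chain carbon, the same change that was made from compound 1 to compound 2. The two cores differ by oxolan-3-yl in place of methyl on an oxygen on an aromatic ring. The expected step of a 2.0-fold higher number from compound 3 to compound 4 (0.31 log units; beyond the scatter) in this assay rests on the earlier step of a 2.2-fold higher number from compound 1 to compound 2 (0.34 log units; beyond the scatter), read as a modest weakening of inhibition carried over to the core of compound 3. On that basis compound 4 is estimated at 9000 nM, with a plausible span from 4500 nM to 18000 nM.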

Compound 4, half-maximal inhibitory concentration: 7180 nM
Compound 4: the middle estimate sits 1.3-fold (0.10 log units) above what was measured, and the stated range covers the measured number.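

In this assay, 4-methylpiperazin-1-yl in place of piperidin-1-yl on the core of compound 3 gave a 1.6-fold higher number from compound 3 to compound 4 (0.21 log units; within the scatter), and this reading of the change agrees with the earlier one: the same change on two cores in this assay, a 2.2-fold higher number (0.34 log units; beyond the scatter) from compound 1 to compound 2 and a 1.6-fold higher number (0.21 log units; within the scatter) from compound 3 to compound 4, 1.3-fold (0.13 log units) apart, within the scatter of two such steps. Oxolan-3-yl in place of methyl on an oxygen on an aromatic ring gave a 1.2-fold lower number from compound 2 to compound 4 (0.08 log units; within the scatter), and this change also reads alike on both cores: the same change on two cores in this assay, a 1.1-fold higher number (0.05 log units; within the scatter) from compound 1 to compound 3 and a 1.2-fold lower number (0.08 log units; within the scatter) from compound 2 to compound 4, 1.3-fold (0.13 log units) apart, within the scatter of two such steps. The two changes therefore carry from one core to the other in this series without a detectable difference, but the step on the core of compound 3 lies within the scatter, so the data do not establish on its own that the amine swap weakens inhibition on that core, and two cores in one assay cannot show that the agreement extends further.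

As far as these compounds go, it remains open whether other amines on the same chain, such as morpholin-4-yl or dimethylamino, would behave as these two do. From the compounds shown here alone, it is equally open whether a larger ether on that oxygen, such as oxan-4-yl, would leave the numbers as close as oxolan-3-yl does.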